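Moving the Nitro Group from Compound 3 to Compound 4

This account rests on a few compounds, and the source may have more. Where it says the series, first, only, none or still open, it means among the compounds named here.

In a functional assay on NSCLC cells (Homo sapiens) for antiproliferative activity (a higher number here means a weaker inhibitor, a lower number a stronger inhibitor), compound 1 (`N#CN/C(=N\CCCCCCCOc1ccccc1)Nc1ccncc1`) gives 0.6 nM and compound 2 (`N#CN/C(=N\CCCCCCCOc1ccccc1)Nc1cccnc1`) gives 22 nM. Compound 3 (`N#CN/C(=N\CCCCCCOc1ccccc1[N+](=O)[O-])Nc1ccncc1`) gives 0.6 nM, level with compound 1, and these two share the lowest number of the three. Compound 4 (`N#CN/C(=N\CCCCCCOc1cccc([N+](=O)[O-])c1)Nc1ccncc1`) has the same atoms joined differently: 3-nitrophenyl in place of 2-nitrophenyl on an oxygen on a saturated carbon, with 3-nitrophenyl in place of 2-nitrophenyl on an oxygen on a saturated carbon. Among the compounds with values here, the only measured step, a 37-fold higher number from compound 1 to compound 2 (1.56 log units; beyond the scatter), put pyridin-3-yl in place of pyridin-4-yl on an amine nitrogen. It shows that such a swap can matter, but it concerns a different group, so only a small rise in this assay is expected. The expected change is a 1.7-fold higher number from compound 3 to compound 4 (0.22 log units; within the scatter). Compound 4 is estimated at 1 nM, within an expected range of 0.3 nM to 5 nM.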

Compound 4, half-maximal inhibitory concentration: 5.7 nM
The estimate for compound 4 lay 5.7-fold (0.76 log units) below the measured number; measured number above the stated range.
By their numbers in this assay, from the lowest: compounds 1 and 3 (each within the scatter of the next); then compound 4; then compound 2.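

Moving the nitro group around the ring, with no atom gained or lost, gives a 9.5-fold higher number from compound 3 to compound 4 (0.98 log units; beyond the scatter). The earlier step showed this sensitivity at the pyridine end of the molecule, and this one shows that the arrangement of atoms also counts at the other end, where 2-nitrophenyl gives way to 3-nitrophenyl. Nothing available explains this difference. As far as these compounds go, whether an amine or a carboxylic acid in place of the nitro group would match compound 3 stays open. So does whether a longer chain would change the size of this step.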